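Furan in place of dimethylaminophenyl on the shared core

The compounds below may be only part of what the source reports. "The series", "measured", "known", "first", "only" and "open" are said of these compounds alone.

Compound 3 `CC(=O)OC[C@H]1O[C@@H](n2cc(CN3C(=O)/C(=C/c4ccc(N(C)C)cc4)c4ccccc43)nn2)[C@H](OC(C)=O)[C@@H](OC(C)=O)[C@@H]1OC(C)=O` gives 25200 nM in a functional assay on MCF7 cells (Homo sapiens) for cytotoxicity, read by sulforhodamine B assay, with a stated time of 48 h (on this read-out lower numbers stand for stronger inhibition and higher numbers for weaker inhibition), the lowest of the two numbers in hand. Compound 2 `CC(=O)OC[C@H]1O[C@@H](n2cc(CN3C(=O)/C(=C\c4ccc(N(C)C)cc4)c4ccccc43)nn2)[C@H](OC(C)=O)[C@@H](OC(C)=O)[C@@H]1OC(C)=O` gives 29800 nM in this assay; the step of a 1.2-fold lower number from compound 2 to compound 3 (0.07 log units; within the scatter) rests on the fact that compounds 2 and 3 differ only in the configuration as drawn and lies within the scatter. Compound 1 `COc1ccc2c(c1)c(C=O)cn2Cc1cn([C@@H]2O[C@H](COC(C)=O)[C@@H](OC(C)=O)[C@H](OC(C)=O)[C@H]2OC(C)=O)nn1` gives only a limit, > 200000 nM, in this assay. Compound 4 `CC(=O)OC[C@H]1O[C@@H](n2cc(CN3C(=O)/C(=C/c4ccco4)c4ccccc43)nn2)[C@H](OC(C)=O)[C@@H](OC(C)=O)[C@@H]1OC(C)=O` carries furan-2-yl in place of 4-(dimethylamino)phenyl on a double-bonded chain carbon bound to a double-bonded ring carbon. Going by the values given here, no measured step changes the group on the double-bonded chain carbon: the one step in hand, a 1.2-fold lower number from compound 2 to compound 3 (0.07 log units; within the scatter), concerns configuration alone, so it gives no direction for this replacement. The step of a 1.4-fold higher number from compound 3 to compound 4 (0.14 log units; within the scatter) is therefore expected to stay near the scatter. Compound 4 is estimated at 35000 nM in this assay, with a range from 10000 nM to 120000 nM.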

Compound 4, half-maximal inhibitory concentration: 29100 nM
Beside the measured number, compound 4's estimate is 1.2-fold (0.08 log units) above it; low and high end bracket the measured number.
By their numbers in this assay, from the lowest: compounds 3, 4 and 2 (each within the scatter of the next). At a limit, above all of these: compound 1.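

In this assay, going by these compounds alone, the first change of group on the double-bonded chain carbon, furan-2-yl in place of 4-(dimethylamino)phenyl, gives a 1.2-fold higher number from compound 3 to compound 4 (0.06 log units; within the scatter). The earlier step concerned configuration alone; this one shows that a five-membered aromatic ring with one hetero atom and the substituted six-membered carbon ring cannot be told apart at this position. Nothing in hand bears on why the number holds across this replacement.

Going by these compounds, whether a carboxylic acid, a primary amine or a longer chain on this carbon would move the number beyond the scatter stays open. Also open, on these data alone, is how a furan-2-yl compound with the double bond drawn Z compares with compound 4.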